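Cytotoxicity of salicylanilides with varied para substituents

A few compounds are considered here, and "the series" means these few. Any claim that something is new, unique, unknown or untested is made for them only; others in the source may bear on it.

Measured compounds:
compound 1 `CN(C)c1ccc(NC(=O)c2cc(Cl)ccc2O)c(Cl)c1`, 85100 nM
compound 2 `CC1(ON(c2ccc(NC(=O)c3cc(Cl)ccc3O)c(Cl)c2)C2(C)CCCC2)CCCC1`, 18000 nM
compound 3 `O=C(Nc1ccc(NCc2cc(C(F)(F)F)cc(C(F)(F)F)c2)cc1Cl)c1cc(Cl)ccc1O`, 92800 nM

In an ADME assay on A549 cells (Homo sapiens) for cytotoxicity, read by resazurin assay, with a stated time of 48 h (on this read-out higher numbers stand for lower toxicity in this test and lower numbers for higher toxicity in this test), compound 1 gives 85100 nM. Compound 1 stands second highest of the three numbers; compound 3 lies within the scatter of it, while compound 2 sits well below, beyond the scatter. Compound 4 `O=C(Nc1ccc(NCc2cnccc2Cl)cc1Cl)c1cc(Cl)ccc1O` has not yet been measured. Its change from compound 1 is ((4-chloropyridin-3-yl)methyl)amino in place of dimethylamino on an aromatic carbon. Compound 3 carries a related group at the same position and gives 92800 nM, close to compound 1, so for a 1.1-fold lower number from compound 1 to compound 4 (0.03 log units; within the scatter) a step of no size beyond the scatter is expected. For compound 4 in this assay the expected value is 80000 nM, with a range from 35000 nM to 180000 nM.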

Compound 4, half-maximal cytotoxic concentration: 126000 nM
Estimate against measurement, compound 4: 1.6-fold (0.20 log units) below, and the stated range covers the measured number.
By their numbers in this assay, from the lowest: compound 2; then compounds 1, 3 and 4 (each within the scatter of the next).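

In this assay, putting ((4-chloropyridin-3-yl)methyl)amino in place of dimethylamino gives a 1.5-fold higher number from compound 1 to compound 4 (0.17 log units; within the scatter), the first single-place step available in this series. At this aromatic carbon, then, a much larger group bringing a six-membered aromatic ring and a hydrogen-bond donor makes no difference that can be told from the scatter. Nothing measured here offers an explanation for this result. Still open, from the compounds shown here alone, is how a simple unsubstituted amine or a carboxylic acid at the same position would read, and whether any single-place change here moves the number beyond the scatter.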